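Working notes: replacing the nitrooxy end of compound 1

The source may hold more compounds than are shown below. What is called first, only, known or untested is meant among the compounds shown, and "the series" means these compounds.

Measured so far in a functional assay (aorta) with Rattus norvegicus as the target, in the presence of a further agent that is not named here; on this read-out higher numbers stand for an effect only at larger amounts of compound and lower numbers for an effect already at smaller amounts
- compound 1 `COC(=O)C1=C(C)N=C(C)/C(=C(/O)OC)C1c1ccccc1OCCO[N+](=O)[O-]` gives 56 nM
- compound 2 `COC(=O)C1=C(C)N=C(C)/C(=C(/O)OC)C1c1cccc(OCc2c(C(N)=O)no[n+]2[O-])c1` gives 1200 nM

Of these two numbers, compound 1 at 56 nM holds the lower, so it responds at the smaller amount. The gap up to compound 2 lies beyond the usual scatter, but these two compounds differ in more than one place. Going by the values given here, the series therefore offers no measured step that isolates a single change.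

The next compound to be read is compound 3 `COC(=O)C1=C(C)N=C(C)/C(=C(/O)OC)C1c1ccccc1OCc1nonc1C` on the core of compound 1. In it, 4-methyl-1,2,5-oxadiazol-3-yl stands in place of (nitrooxy)methyl on a saturated chain carbon bound to an oxygen on an aromatic ring 4-methyl-1,2,5-oxadiazol-3-yl in place of (nitrooxy)methyl on a saturated chain carbon bound to an oxygen on an aromatic ring and the rest is unchanged.

Among the compounds with values here, with only two reference values, the expectation is loose. Within the data shown here, compound 1 sits at the low end, and the only other reading, compound 2 at 1200 nM on the high side, suggests that a changed side chain is more likely to raise the number than to lower it. An upward move beyond the scatter is expected, and the estimate is a 4.5-fold higher number from compound 1 to compound 3 (0.65 log units; beyond the scatter) for this change. In this assay compound 3 is estimated at 250 nM with an expected range of 40 nM to 1500 nM for the coming measurement.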

Compound 3, half-maximal effective concentration: 41 nM
Compound 3: the middle estimate sits 6.1-fold (0.79 log units) above what was measured, within the range that was stated.
By their numbers in this assay, from the lowest: compounds 3 and 1 (each within the scatter of the next); then compound 2.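

In this assay, the series now has its first step that changes one place only, and it reads a 1.4-fold lower number from compound 1 to compound 3 (0.14 log units; within the scatter) on the core of compound 1. On a saturated chain carbon bound to an oxygen on an aromatic ring, 4-methyl-1,2,5-oxadiazol-3-yl and (nitrooxy)methyl therefore cannot be told apart in this assay, and compound 3 gives 41 nM with no nitrooxy group in the molecule, so a number of this size does not depend on that end. Nothing measured here bears on why the two groups read alike.

The compounds shown leave open whether this tolerance extends to groups unrelated to these two, such as a simple propyl chain, a hydroxyethyl chain or a dimethylamino end at the same place. They also leave open what the methyl on the 4-methyl-1,2,5-oxadiazol-3-yl ring contributes, and a step to a close partner of compound 3 carrying a carboxylic acid or a hydrogen in place of that methyl would address this.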